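Aryl urea substituent series: chloro to iodo

The source may report more compounds than this note shows. Statements on the series, on what has been measured and on what is new or still open speak of the compounds shown alone.

Compound 1 `CCc1nc2ccccc2c(=O)n1NC(=O)Nc1ccccc1` gives 54% in a functional assay on the whole organism (strain albino) with Mus musculus as the target, at a dose of 100 mg/kg by the intraperitoneal route; on this read-out higher numbers stand for more inhibition at the one dose given (going by the name of the read-out) and lower numbers for less inhibition. Compound 2 `CCc1nc2ccccc2c(=O)n1NC(=O)Nc1ccc(C)cc1` gives 55% and compound 3 `CCc1nc2ccccc2c(=O)n1NC(=O)Nc1ccc(Cl)cc1` gives 52% in this assay. The three numbers lie close together: a number 1 percentage points higher from compound 1 to compound 2 (within the scatter), a number 2 percentage points lower from compound 1 to compound 3 (within the scatter) and a number 3 percentage points lower from compound 2 to compound 3 (within the scatter), so compound 3 stands within the usual scatter of the other two. Compound 4 `CCc1nc2ccccc2c(=O)n1NC(=O)Nc1ccc(I)cc1` is not yet measured and differs from compound 3 by iodo in place of chloro on an aromatic carbon. Going by the values given here, no measured step exchanges one halogen for another; the nearest comparisons are the three steps at this aromatic carbon, none of which leaves the scatter, so no step beyond the scatter is expected in this assay. The expected step is a number 1 percentage points higher from compound 3 to compound 4 (within the scatter). The estimate for compound 4 in this assay is 53%, between 43% and 63%.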

Compound 4, a percentage reported as inhibition, in the whole organism at one dose (the size of the read-out at that dose, not a potency): 55%
Compound 4: the middle estimate sits 2 percentage points below what was measured; low and high end bracket the measured number.
By their numbers in this assay, from the lowest: compounds 3, 1, 2 and 4 (each within the scatter of the next).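

In this assay, iodo on this aromatic carbon, para to a large group, reads level with the other three substituents: a number 3 percentage points higher from compound 3 to compound 4 (within the scatter), no change at the digits printed from compound 2 to compound 4 (within the scatter) and a number 1 percentage points higher from compound 1 to compound 4 (within the scatter). Going by these compounds alone, the first exchange of one halogen for another thus also stays within the scatter, and hydrogen, methyl, chloro and iodo cannot be told apart here. No measured evidence bears on this flat result.

As far as these compounds go, whether a carboxylic acid or an amine on this carbon would leave the scatter remains open. So does the effect of a longer chain on the shared core.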